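The compounds below may be only part of what the source reports. "The series", "measured", "known", "first", "only" and "open" are said of these compounds alone.

Of the compounds shown here, two of one series have been measured in a functional assay on cells (Erythrocyte, Homo sapiens) for inhibition, read by spectrophotometry and hemolysis, with a stated time of 10 min; on this read-out higher numbers stand for weaker inhibition and lower numbers for stronger inhibition. Compound 1, `O=C(CCc1nc2ccccc2c(=O)[nH]1)N/N=C/c1ccc(Cl)cc1`, gives 84000000 nM in this assay. Compound 2, `O=C(CCCc1nc2ccccc2c(=O)[nH]1)N/N=C/c1ccc([N+](=O)[O-])cc1`, gives 52000000 nM in this assay. Compound 1 stands at the highest of the two numbers, but compound 2 lies within the usual scatter of it, so the pair shows no separation. Compound 3, `O=C(CCc1nc2ccccc2c(=O)[nH]1)N/N=C/c1ccc(O)c(O)c1`, has not yet been measured in this assay. It differs from compound 1 in one place: 3,4-dihydroxyphenyl in place of 4-chlorophenyl on a carbon with a double bond to nitrogen. Among the compounds with values here, no step between two measured compounds bears on this change, so its direction is open; the series so far gives only weak inhibition. The expected step of a 2.1-fold lower number from compound 1 to compound 3 (0.32 log units; beyond the scatter) is a modest lowering, possibly not beyond the scatter. Compound 3 is expected to give about 40000000 nM in this assay, with a likely range from 10000000 nM to 150000000 nM.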

Compound 3, half-maximal inhibitory concentration: 255000000 nM
Compound 3: the middle estimate sits 6.4-fold (0.80 log units) below what was measured; measured number outside the range, above it.
By their numbers in this assay, from the lowest: compounds 2 and 1 (each within the scatter of the next); then compound 3.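

The aromatic group on a carbon with a double bond to nitrogen now has its first readable step: in this assay, 3,4-dihydroxyphenyl in place of 4-chlorophenyl gives weaker inhibition (a 3.0-fold higher number from compound 1 to compound 3 (0.48 log units; beyond the scatter)). The number at this position therefore responds to the group it carries, which the earlier pair could not show, as compounds 1 and 2 differ in two places. The entering group counts 2 hydrogen-bond donors and 2 hydrogen-bond acceptors against 0 of each in the group it replaces, yet this single pair sets no trend.

Going by these compounds, one step cannot separate the gain of the two hydroxyl groups from the loss of the chlorine, and the effect of an amine or a carboxylic acid on that ring remains open. No measurement at hand accounts for the rise.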